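A few compounds are considered here, and "the series" means these few. Any claim that something is new, unique, unknown or untested is made for them only; others in the source may bear on it.

Measured compounds in an assay on Sf9 cells for inhibition of serine/threonine-protein kinase 4 (Homo sapiens), read by luminescence and ADP-Glo, with a stated time of 1 h, in the presence of a further agent that is not named here; on this read-out lower numbers stand for stronger inhibition and higher numbers for weaker inhibition: compound 1 `CCC1C(=O)N(C)c2cnc(Nc3ccc(S(N)(=O)=O)cc3)nc2N1C` gives 479 nM; compound 2 `CC(C)CC1C(=O)N(C)c2cnc(Nc3ccc(S(N)(=O)=O)cc3)nc2N1C` gives 77 nM.

Among the measured compounds shown here, only one step has been measured in this assay: a 6.2-fold lower number from compound 1 to compound 2 (0.79 log units; beyond the scatter). Compound 2 therefore holds the lowest number of the two, with compound 1 as its nearest neighbour at a higher number, the gap lying beyond the scatter.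

Compound 3 `CN1C(=O)C(c2ccc(F)cc2)N(C)c2nc(Nc3ccc(S(N)(=O)=O)cc3)ncc21` has not yet been measured. It differs from compound 2 in one place: 4-fluorophenyl in place of isobutyl on a saturated ring carbon. The step from compound 1 to compound 2 is the only one that bears on this change, and it shows that a larger group on this saturated ring carbon gave a clearly lower number. The new group in compound 3 is larger still but is aromatic rather than a branched chain, so the measured step is only a partial guide; a modest further lowering or no change beyond the scatter seems the likelier outcome. Compound 3 is expected to give about 50 nM in this assay, within 10 nM to 250 nM, which means an estimated step of a 1.5-fold lower number from compound 2 to compound 3 (0.19 log units; within the scatter).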

Compound 3, half-maximal inhibitory concentration: 1770 nM
For compound 3 the middle estimate is 35-fold (1.55 log units) below the measured one; measured number above the stated range.
By their numbers in this assay, from the lowest: compound 2; then compound 1; then compound 3.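

In this assay, a larger group at this saturated ring carbon does not by itself bring a lower number: 4-fluorophenyl in place of isobutyl gives a 23-fold higher number from compound 2 to compound 3 (1.36 log units; beyond the scatter), and 4-fluorophenyl in place of ethyl gives a 3.7-fold higher number from compound 1 to compound 3 (0.57 log units; beyond the scatter). The earlier step, a 6.2-fold lower number from compound 1 to compound 2 (0.79 log units; beyond the scatter), held only for the two open chains, and compound 3, with the most heavy atoms of the three groups and the only aromatic ring, goes against that trend by holding the highest number. Nothing measured here explains this reversal.

Open, on these data alone, is whether a plain phenyl, a benzyl or a cyclohexyl group would sit closer to 4-fluorophenyl or to isobutyl. Also open, as far as these compounds go, is whether a longer chain than isobutyl would lower the number further or raise it.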